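The source may hold more compounds than are shown below. What is called first, only, known or untested is meant among the compounds shown, and "the series" means these compounds.

Measured so far:
compound 1, `C#CCCOC(=O)/C=C/c1ccc(OC(C)=O)c(OC(C)=O)c1`: 1800 nM
compound 2, `C#CCCCCOC(=O)/C=C/c1ccc(OC(C)=O)c(OC(C)=O)c1`: 920 nM

Both numbers come from an assay for inhibition of Polyunsaturated fatty acid 5-lipoxygenase (Homo sapiens), read by HPLC, with a stated time of 10 min; on this read-out higher numbers stand for weaker inhibition and lower numbers for stronger inhibition. Among the compounds with values here, the only step in hand is a 2.0-fold lower number from compound 1 to compound 2 (0.29 log units; within the scatter); compound 2 therefore sits within the scatter of compound 1, and neither can be called the stronger inhibitor on this evidence. Where compound 2 stands is simply the lower end of two numbers that the scatter does not separate.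

Compound 3, `C#CCCCCCOC(=O)/C=C/c1ccc(OC(C)=O)c(OC(C)=O)c1`, has not yet been measured in this assay. It differs from compound 2 by propargyl in place of ethynyl on a saturated chain carbon, four bonds along the chain from an oxygen next to a carbonyl group. Within the data shown here, the same kind of change, read one bond further out, is exactly what the single measured step covered, a 2.0-fold lower number from compound 1 to compound 2 (0.29 log units; within the scatter), and that step stayed within the scatter. One such step gives no ground to expect more from the next extension of the chain. For compound 3 the expected step is a 1.2-fold lower number from compound 2 to compound 3 (0.09 log units; within the scatter), that is, nothing beyond the scatter, with only a slight lean in the direction of the earlier step. Compound 3 is estimated at 750 nM in this assay, with a range from 350 nM to 1600 nM.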

Compound 3, half-maximal inhibitory concentration: 470 nM
The estimate for compound 3 lay 1.6-fold (0.20 log units) above the measured number, within the range that was stated.
By their numbers in this assay, from the lowest: compounds 3, 2 and 1 (each within the scatter of the next, the first and the last beyond it).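

At this position, propargyl in place of ethynyl on a saturated chain carbon, four bonds along the chain from an oxygen next to a carbonyl group, gives a 2.0-fold lower number from compound 2 to compound 3 (0.29 log units; within the scatter) in this assay and so does not separate the two neighbouring compounds when read alone. Read across both extensions, the change in the chain gives a 3.8-fold lower number from compound 1 to compound 3 (0.58 log units; beyond the scatter) and is the first step in the series to pass the scatter, so chain length at this position now has a modest measured link to the number, with no compound shown going against it. No measurement shown accounts for this link between chain length and the number.

Still open, as far as these compounds go, is whether a longer chain carries the same direction further or whether the link ends beyond compound 3. The compounds shown also leave open whether the terminal triple bond matters at all, as a saturated alkyl chain, an amine or a carboxylic acid at the chain end would show, and whether the two acetyl groups on the shared core matter.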